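A few compounds are considered here, and "the series" means these few. Any claim that something is new, unique, unknown or untested is made for them only; others in the source may bear on it.

For the measured compounds named here, compound 1 `COc1ccc([C@@H]2C/C(=N/OCc3cn(-c4cccc(CO)c4)nn3)c3cc(CC=C(C)C)c(OC)cc3O2)cc1` has the lower of the two numbers measured so far: in a functional assay on HCT-116 cells (Homo sapiens) for inhibition, read by sulforhodamine B assay, with a stated time of 48 h, tested at 50 uM (a lower number here means less inhibition of growth, a higher number more inhibition of growth at the concentration tested), compound 1 gives 27%. Compound 2 `CCCCOc1ccc([C@@H]2CC(=O)c3cc(CC=C(C)C)c(OC)cc3O2)cc1` gives 60% in this assay, a gap that lies beyond the usual scatter. Compound 3 `COc1ccc([C@@H]2C/C(=N/OCc3cn(-c4ccc(C(N)=O)cc4)nn3)c3cc(CC=C(C)C)c(OC)cc3O2)cc1` differs from compound 1 by a single exchange, (4-carbamoylphenyl in place of 3-(hydroxymethyl)phenyl on an aromatic nitrogen). Going by the values given here, no measured pair shows this exchange, so its effect is unknown; the step is expected to be small, in no clear direction and not beyond the scatter. The expected step of a number 1 percentage points higher from compound 1 to compound 3 (within the scatter) reflects this. Compound 3 is therefore estimated to give 28% in this assay, within 14% to 45%.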

Compound 3, percent growth inhibition at one concentration: 100%
Compound 3: middle estimate off by 72 percentage points, on the low side; the measured number lies above the stated range.
By their numbers in this assay, from the lowest: compound 1; then compound 2; then compound 3.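

In this assay, 4-carbamoylphenyl in place of 3-(hydroxymethyl)phenyl brings a number 73 percentage points higher from compound 1 to compound 3 (beyond the scatter). This position on the five-membered aromatic ring is therefore far from indifferent: a single exchange here, with the rest of the molecule unchanged, has a large effect on growth inhibition. Nothing available explains the step.

The exchange alters both the group and its place on the phenyl ring, so the two contributions cannot be separated. On these data alone, whether a carboxylic acid or an amine on that ring would give similar inhibition remains open.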